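Aryl substituent swaps on the shared core: compound 4

The compounds below may be only part of what the source reports. "The series", "measured", "known", "first", "only" and "open" are said of these compounds alone.

The series keeps the shared core of compound 1 `CCCS(=O)(=O)Nc1ccc(F)c(C(=O)c2n[nH]c3ncc(-c4cccc(C)c4)cc23)c1F` and changes only the aryl group on it. Going by the values given here, in an assay for binding affinity to dual specificity mitogen-activated protein kinase kinase 4 (Homo sapiens), read by KINOMEscan, tested at 100 nM (on this read-out higher numbers stand for a weaker effect at the one concentration tested and lower numbers for a stronger effect), compound 1 gives 15%, the highest of the three numbers measured so far. Compound 2 `CCCS(=O)(=O)Nc1ccc(F)c(C(=O)c2n[nH]c3ncc(-c4ccccc4OC)cc23)c1F` gives 1.9% in this assay, and compound 3 `CCCS(=O)(=O)Nc1ccc(F)c(C(=O)c2n[nH]c3ncc(-c4ccccc4O)cc23)c1F` gives 9%. Of the measured steps, only a number 13.1 percentage points lower from compound 1 to compound 2 (beyond the scatter) is beyond the scatter; a number 6 percentage points lower from compound 1 to compound 3 (within the scatter) and a number 7.1 percentage points higher from compound 2 to compound 3 (within the scatter) are within it.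

Compound 4 `CCCS(=O)(=O)Nc1ccc(F)c(C(=O)c2n[nH]c3ncc(-c4cccc(N)c4)cc23)c1F` differs from compound 1 by amino in place of methyl on an aromatic carbon. Among the compounds with values here, no measured step makes this exact change. The two steps that start from compound 1 both replace 3-methylphenyl with another substituted phenyl, and both moved the number lower in this assay, one beyond the scatter and one within it. On that basis a small step lower, most likely within the scatter, is expected for compound 4, namely a number 5 percentage points lower from compound 1 to compound 4 (within the scatter). The estimate for compound 4 in this assay is 10%, with an expected range from 2% to 25%.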

Compound 4, a percentage reported as activity, at one concentration (the size of the read-out at that concentration, not a potency): 1.6%
Estimate against measurement, compound 4: 8.4 percentage points above; the whole stated range lies above it.
By their numbers in this assay, from the lowest: compounds 4, 2, 3 and 1 (each within the scatter of the next, the first and the last beyond it).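

In this assay, amino in place of methyl gives a number 13.4 percentage points lower from compound 1 to compound 4 (beyond the scatter), so a change of one heavy atom on the 3-methylphenyl group, with the substituent staying in the same place on the ring, is enough to move the read-out beyond the scatter. The 3-aminophenyl group cannot be separated from the two 2-substituted phenyl groups, as the steps are a number 7.4 percentage points lower from compound 3 to compound 4 (within the scatter) and a number 0.3 percentage points lower from compound 2 to compound 4 (within the scatter), so among these compounds a low number is not tied to one substituent place. Nothing measured on this change accounts for the step from methyl to amino.

Open, going by these compounds, is whether a 3-hydroxyphenyl or 3-methoxyphenyl group would behave like 3-aminophenyl. Also open, on these data alone, is whether a dimethylamino group or an acetamide at that place would keep the low number.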